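The compounds below may be only part of what the source reports. "The series", "measured", "known", "first", "only" and "open" are said of these compounds alone.

Compound 1 `CCC(C)(O)CC(=O)O[C@H](CC=C(C)C)C1=CC(=O)c2c(O)ccc(O)c2C1=O` in a functional assay on DU-145 cells (Homo sapiens) for cytotoxicity, read by MTT assay (a lower number here means a stronger inhibitor, a higher number a weaker inhibitor), gives 16000 nM.
Compound 2 `CC(C)=CC[C@@H](OC(=O)CC(C)(O)c1ccccc1)C1=CC(=O)c2c(O)ccc(O)c2C1=O` in this assay gives only a limit of the assay, > 100000 nM.
Compound 3 `CC(C)=CC[C@@H](OC(=O)c1ccco1)C1=CC(=O)c2c(O)ccc(O)c2C1=O` in this assay gives only a limit of the assay, > 100000 nM.

Compound 3 thus rests on the limit of > 100000 nM in this assay, at which 2 of the 3 values shown sit, and has no number of its own. Compound 4 `CC(C)=CC[C@@H](OC(=O)CCO)C1=CC(=O)c2c(O)ccc(O)c2C1=O` differs from it by 2-hydroxyethyl in place of furan-2-yl on a carbonyl carbon. The step that bears on this position is an at least 6.2-fold higher number from compound 1 to compound 3 (0.79 log units; beyond the scatter), where a hydroxy-bearing chain was swapped for the furan-2-yl ring and the number rose past the limit, while a step that the two limits leave unreadable from compound 2 to compound 3 gives no readable size. Since compound 4 brings a hydroxy-bearing chain back to the carbonyl carbon, a fall in the number toward compound 1 is expected, though a limit remains possible. Compound 4 is therefore estimated at 35000 nM, with a range from 8000 nM to 100000 nM, an expected step of an at least 2.8-fold lower number from compound 3 to compound 4 (0.45 log units; beyond the scatter).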

Compound 4, half-maximal inhibitory concentration: 55300 nM
Compound 4: the middle estimate sits 1.6-fold (0.20 log units) below what was measured; measured number inside the range.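

Compound 4 shows that a short hydroxy-bearing chain with no ring on this carbonyl carbon gives a real number in this assay, whereas compounds 2 and 3 rest only on a limit: the limit of > 100000 nM in this assay, at which 2 of the 4 values shown sit.

Against those limits, the change can be read only as an at least 1.8-fold lower number from compound 3 to compound 4 (0.25 log units; that floor lies within the scatter) and as an at least 1.8-fold lower number from compound 2 to compound 4 (0.25 log units; that floor lies within the scatter), so neither step alone establishes a real gain. The step of a 3.5-fold higher number from compound 1 to compound 4 (0.54 log units; beyond the scatter) shows that a hydroxy-bearing chain does not by itself match compound 1.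

Which part of the larger chain of compound 1 accounts for that gap remains open. So does how an amine or a carboxylic acid would read in place of the hydroxy group.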